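Replacing the tert-butyl side chain in the benzyl ether amide series

The source may report more compounds than this note shows. Statements on the series, on what has been measured and on what is new or still open speak of the compounds shown alone.

Measured so far:
compound 1 `CC(C)(C)[C@@H](N)C(=O)NCc1ccc(COc2cccc(F)c2)cc1` – 30 mg/kg
compound 2 `CC(C)(C)[C@@H](N)C(=O)NCc1ccc(OCc2cccc(F)c2)cc1` – > 30 mg/kg
compound 3 `CC(C)(C)[C@@H](N)C(=O)NCc1ccc(OC(F)(F)F)cc1` – 23 mg/kg

In a functional assay on the whole organism (strain albino Sprague-Dawley) with Rattus norvegicus as the target, in the maximal electroshock model (on this read-out higher numbers stand for an effect only at larger amounts of compound and lower numbers for an effect already at smaller amounts), compound 1 gives 30 mg/kg. Compound 3 gives 23 mg/kg in the same assay. For the measured compounds named here, for compound 2 only a limit is recorded, > 30 mg/kg, so its standing on the numbers is open: it sits at the limit of > 30 mg/kg in this assay, at which 1 of the 3 values shown sits, and it is the one compound of the three for which no number is available. Going by the values given here, the single measured step, an at least 1.3-fold lower number from compound 2 to compound 3 (0.11 log units; that floor lies within the scatter), concerns the oxygen substituent on the aromatic ring and has a floor within the scatter.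

Compound 4 `COC[C@@H](N)C(=O)NCc1ccc(OCc2cccc(F)c2)cc1` differs from compound 2 elsewhere: methoxymethyl in place of tert-butyl on a saturated chain carbon bound to an amine nitrogen and a carbonyl carbon. Among the compounds with values here, none of the measured steps touches this position, so nothing measured bears directly on the size or direction to be expected in this assay. Within the data shown here, the only anchor is compound 2 itself, which is a limit and not a number.

Compound 4 is therefore expected to land close to the limit seen for compound 2, the estimated step being a step that the limit leaves unreadable from compound 2 to compound 4, with a fair chance that again only a limit is reported. The estimate for compound 4 is 40 mg/kg, with a range from 15 mg/kg to 120 mg/kg.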

Compound 4, dose for half-maximal effect: 13 mg/kg
The estimate for compound 4 lay 3.1-fold (0.49 log units) above the measured number; measured number below the stated range.
By their numbers in this assay, from the lowest: compounds 4, 3 and 1 (each within the scatter of the next, the first and the last beyond it).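

In this assay, methoxymethyl in place of tert-butyl on the saturated chain carbon bound to an amine nitrogen and a carbonyl carbon gives an at least 2.3-fold lower number from compound 2 to compound 4 (0.36 log units; beyond the scatter), the only step shown whose floor lies beyond the scatter. The tert-butyl group is therefore not required for activity at this position: with the rest of compound 2 unchanged, a side chain of 3 heavy atoms with 1 hydrogen-bond acceptor, in place of 4 heavy atoms with none, brings the effect to smaller amounts of compound. The true size of the step stays unread, since compound 2 is recorded only as a limit and not a number: the limit of > 30 mg/kg in this assay, at which 1 of the 4 values shown sits.

One pair cannot separate the oxygen of methoxymethyl from the change in chain size, and an ethyl or a hydroxymethyl group on the same carbon would bear on that question. From the compounds shown here alone, it also remains open whether methoxymethyl in place of tert-butyl gives a step of the same direction on the cores of compound 1 and compound 3.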